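The compounds below may be only part of what the source reports. "The series", "measured", "known", "first", "only" and "open" are said of these compounds alone.

Compound 1, `Cc1ccc(CCC(=O)N[C@@H](C(=O)N2CCC(c3ccc(Cl)cc3)CC2)C(C)C)cc1`, sits at the weak end of the three compounds that have been measured. In an assay on THP-1 cells for displacement of a labelled ligand from C-C chemokine receptor type 1 (Homo sapiens) (a higher number here means a weaker inhibitor, a lower number a stronger inhibitor), compound 1 gives 105 nM, a higher number than either of its companions. Compound 2, `Cc1ccccc1C(=O)NC(C(=O)N1CCC(c2ccc(Cl)cc2)CC1)C(C)C`, gives 36 nM in this assay, and compound 3, `CC[C@@H](C)[C@@H](NC(=O)c1ccccc1)C(=O)N1CCC(c2ccc(Cl)cc2)CC1`, gives 45 nM; both of these gaps to compound 1 lie beyond the usual scatter, so compound 1 is the least potent of the three by the numbers shown.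

Compound 4, `CC(C)CC(=O)N[C@@H](C(=O)N1CCC(c2ccc(Cl)cc2)CC1)C(C)C`, keeps the core of compound 1 and alters only the acyl group: isopropyl in place of 4-methylbenzyl on a saturated chain carbon bound to a carbonyl carbon. The aromatic ring that was present in compound 1 is gone, and a short branched chain stands in its place.

For the measured compounds named here, no step between two measured compounds tracks this particular change, so the direction rests on judgment alone. Both measured compounds that are stronger than compound 1 carry an aromatic ring in the acyl part; compound 4 carries none. The step from compound 1 to compound 4 is therefore expected to run toward weaker binding, by roughly a 2.9-fold higher number from compound 1 to compound 4 (0.46 log units; beyond the scatter). Compound 4 is expected to give about 300 nM in this assay, with a plausible span from 100 nM to 1000 nM.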

Compound 4, half-maximal inhibitory concentration: 32 nM
For compound 4 the middle estimate is 9.4-fold (0.97 log units) above the measured one, and the stated range ends above it.
By their numbers in this assay, from the lowest: compounds 4, 2 and 3 (each within the scatter of the next); then compound 1.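

In this assay the place on a saturated chain carbon bound to a carbonyl carbon does not depend on an aromatic ring: with isopropyl in place of 4-methylbenzyl, the number runs a 3.3-fold lower number from compound 1 to compound 4 (0.52 log units; beyond the scatter), a modest step. For the compounds shown here, this is the first step read at this place, and here the group goes from 8 heavy atoms to 3 and loses its ring while the number falls. Nothing measured here accounts for the direction of this step.

The compounds shown leave open whether the loss of the ring or the smaller size of the group goes with the lower number, as this one step changes both together. Cyclohexyl at this place would keep a ring without the aromatic one, while an amine or a carboxylic acid on the isopropyl chain remains untested territory here.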